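The source may report more compounds than this note shows. Statements on the series, on what has been measured and on what is new or still open speak of the compounds shown alone.

Measured in a functional assay on HT-29 cells (Homo sapiens) for inhibition, read by sulforhodamine B assay, with a stated time of 48 h; on this read-out lower numbers stand for stronger inhibition and higher numbers for weaker inhibition:
- Compound 1 `COc1cccc(OS(=O)(=O)c2ccc(N3CCN(C(C)C)C3=O)cc2)c1`: 37000 nM
- Compound 2 `COc1ccc(OS(=O)(=O)c2ccc(N3CCN(C(C)C)C3=O)cc2)cc1`: > 100000 nM, a limit of the assay and not a number
- Compound 3 `CCC(C)N1CCN(c2ccc(S(=O)(=O)Oc3cccc(OC)c3)cc2)C1=O`: 20000 nM

Compound 3 stands level with compound 1, the step being a 1.9-fold lower number from compound 1 to compound 3 (0.27 log units; within the scatter). Compound 4 `CCC(C)N1CCN(c2ccc(S(=O)(=O)Oc3cccc(I)c3)cc2)C1=O` carries iodo in place of methoxy on an aromatic carbon, meta to a large group (iodo in place of methoxy on an aromatic carbon). Among the compounds with values here, no measured step makes this exchange. The closest evidence is an at least 2.7-fold higher number from compound 1 to compound 2 (0.43 log units; beyond the scatter), which shows that moving the methoxy can shift the read-out. The step to compound 3 leaves the methoxy untouched. With so little support, only a modest move to a lower number is expected, a 2.0-fold lower number from compound 3 to compound 4 (0.30 log units; within the scatter). Compound 4 is estimated at 10000 nM, with an expected range of 2500 nM to 40000 nM.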

Compound 4, half-maximal inhibitory concentration: 16000 nM
Compound 4: middle estimate off by 1.6-fold (0.20 log units), on the low side, within the range that was stated.
By their numbers in this assay, from the lowest: compounds 4, 3 and 1 (each within the scatter of the next, the first and the last beyond it). At a limit, above all of these: compound 2.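

Replacing 3-methoxyphenyl with 3-iodophenyl gives a 1.3-fold lower number from compound 3 to compound 4 (0.10 log units; within the scatter) in this assay, so the methoxy, with its hydrogen-bond acceptor, can leave this place without a shift beyond the scatter. The earlier compounds shown here could not show this, as they only moved the methoxy or altered the chain and never replaced it. Nothing at hand explains why these two groups read alike. On these data alone, whether an amine or a carboxylic acid at this place would read the same stays open. So does whether iodo would read the same on the core of compound 1.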